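The source may report more compounds than this note shows. Statements on the series, on what has been measured and on what is new or still open speak of the compounds shown alone.

Working notes on the series.

Compound 2 `COc1ccc(C2=NN(C3=NC(=O)/C(=C4\C(=O)Nc5ccc(Br)cc54)S3)C(c3ccc(Cl)cc3)C2)cc1` is the weaker of the two compounds measured in a functional assay on cells (Cancer cell lines, Homo sapiens) for cytotoxicity, read by sulforhodamine B assay, with a stated time of 48 h; on this read-out higher numbers stand for weaker inhibition of growth and lower numbers for stronger inhibition of growth. In this assay compound 2 gives 7440 nM, the higher of the two numbers. Among the compounds with values here, compound 1 `COc1ccc(C2=NN(C3=NC(=O)/C(=C4\C(=O)Nc5ccc(Cl)cc54)S3)C(c3ccc(OC)cc3)C2)cc1` gives 430 nM in this assay, a difference from compound 2 that lies beyond the scatter; the two compounds differ in more than one place, so no single step is drawn between them.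

Compound 3 `COc1ccc(C2=NN(C3=NC(=O)/C(=C4\C(=O)Nc5ccc(Cl)cc54)S3)C(c3ccc(Cl)cc3)C2)cc1` has not yet been measured. Compared with compound 2 the change is chloro in place of bromo on an aromatic carbon. Within the data shown here, compound 1 also carries chloro at this position, but no step isolates the halogen exchange, so the expectation rests on the values of compound 2 and compound 1 together. The exchange of one halogen for another is expected to give a small step, and the value of compound 3 is estimated at 3000 nM, within 700 nM to 12000 nM. The expected step is a 2.5-fold lower number from compound 2 to compound 3 (0.39 log units; beyond the scatter).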

Compound 3, concentration for total growth inhibition: 450 nM
Estimate against measurement, compound 3: 6.7-fold (0.82 log units) above; measured number outside the range, below it.
By their numbers in this assay, from the lowest: compounds 1 and 3 (each within the scatter of the next); then compound 2.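

On the aromatic carbon of the fused system, where the opening estimate expected little, the halogen matters in this assay: chloro in place of bromo gives a 17-fold lower number from compound 2 to compound 3 (1.22 log units; beyond the scatter), a large step for an exchange of one atom. The other aromatic position, by contrast, tolerates a change of group with no visible effect, since chloro in place of methoxy gives a 1.0-fold higher number from compound 1 to compound 3 (0.02 log units; within the scatter), and so the gap first seen between compound 1 and compound 2 is matched by the halogen step alone. No measurement at hand accounts for the size of the halogen step.

The compounds shown leave open how fluoro, a methyl group or an amine on the fused system's aromatic carbon would compare with chloro and bromo. They also leave open whether the halogen exchange keeps its size on the core of compound 1.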